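This account rests on a few compounds, and the source may have more. Where it says the series, first, only, none or still open, it means among the compounds named here.

Measured so far in a functional assay on PC-3 cells (Homo sapiens), read by MTT assay, with a stated time of 48 h; a higher number here means a weaker inhibitor, a lower number a stronger inhibitor:
- compound 1 `CCn1c(C(=O)NCCN(C)C)ccc1C(CC)(CC)c1ccc(OCC(=O)C(C)(C)C)c(C)c1`: 2300 nM
- compound 2 `CCn1c(C(=O)NCCCN(C)C)ccc1C(CC)(CC)c1ccc(OCC(=O)C(C)(C)C)c(C)c1`: 1600 nM
- compound 3 `CCn1c(C(=O)NCCN)ccc1C(CC)(CC)c1ccc(OCC(=O)C(C)(C)C)c(C)c1`: 480 nM

Compound 3 holds the lowest number of the three, with a 4.8-fold lower number from compound 1 to compound 3 (0.68 log units; beyond the scatter) and a 3.3-fold lower number from compound 2 to compound 3 (0.52 log units; beyond the scatter), both beyond the scatter. By contrast, a 1.4-fold lower number from compound 1 to compound 2 (0.16 log units; within the scatter) stays within the scatter.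

Compound 4 `CCn1c(C(=O)N(C)CC(=O)O)ccc1C(CC)(CC)c1ccc(OCC(=O)C(C)(C)C)c(C)c1` carries (carboxymethyl)(methyl)amino in place of (2-aminoethyl)amino on a carbonyl carbon. Going by the values given here, no measured compound carries the entering group, so no measured step describes this change directly, and the three steps above serve only as a guide to size. Those steps were modest at most, but all of them changed one amine chain for another. Compound 3 also stands at the low end of the series, so a modest move toward a higher number in this assay seems more likely than a further drop, with wide uncertainty. The expected change is a 3.1-fold higher number from compound 3 to compound 4 (0.49 log units; beyond the scatter). For compound 4 the estimated value is 1500 nM, with an expected range from 300 nM to 7000 nM.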

Compound 4, half-maximal inhibitory concentration: 18400 nM
Compound 4: the middle estimate sits 12-fold (1.09 log units) below what was measured, and the stated range ends below it.
By their numbers in this assay, from the lowest: compound 3; then compounds 2 and 1 (each within the scatter of the next); then compound 4.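

In this assay, (carboxymethyl)(methyl)amino in place of (2-aminoethyl)amino on the carbonyl carbon gives a 38-fold higher number from compound 3 to compound 4 (1.58 log units; beyond the scatter) and is a large step, and the comparison with the other two amine chains gives a 12-fold higher number from compound 2 to compound 4 (1.06 log units; beyond the scatter) and an 8.0-fold higher number from compound 1 to compound 4 (0.90 log units; beyond the scatter) as well. None of the steps among the amine chains was large, so this position responded far more to losing the amine chain than to any change within that set of chains. No measurement offered here accounts for the rise.

The compounds shown do not separate the carboxylic acid from the methyl that accompanies it, as neither (carboxymethyl)amino nor (2-aminoethyl)(methyl)amino stands among them. From the compounds shown here alone, whether a methyl ester or a longer carboxylic acid chain would behave like compound 4 also stays open.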